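The compounds below may be only part of what the source reports. "The series", "measured", "known", "first", "only" and "open" are said of these compounds alone.

Compound 3 `O=C(O)Cc1sc(C(c2ccc(F)cc2)c2ccc(F)cc2)nc1-c1cn[nH]c1` gives 16 nM in an in vitro assay on HEK385-7 cells for displacement of a labelled ligand from prostaglandin D2 receptor 2 (Homo sapiens) (on this read-out lower numbers stand for stronger inhibition and higher numbers for weaker inhibition), and stands second highest of the three numbers: compound 1 `COc1cc(-c2nc(C(c3ccc(F)cc3)c3ccc(F)cc3)sc2CC(=O)O)ccn1` at 29 nM lies within the scatter of it, while compound 2 `O=C(O)Cc1sc(C(c2ccc(F)cc2)c2ccc(F)cc2)nc1-c1ccncc1` at 5.3 nM is furthest, a 3.0-fold higher number from compound 2 to compound 3 (0.48 log units; beyond the scatter). Compound 4 `Cc1cc(-c2nc(C(c3ccc(F)cc3)c3ccc(F)cc3)sc2CC(=O)O)cnc1N` differs from compound 3 by 6-amino-5-methylpyridin-3-yl in place of 1H-pyrazol-4-yl on an aromatic carbon. Going by the values given here, the steps that bear on this are a 5.5-fold lower number from compound 1 to compound 2 (0.74 log units; beyond the scatter) and a 3.0-fold higher number from compound 2 to compound 3 (0.48 log units; beyond the scatter), both beyond the scatter, whereas a 1.8-fold lower number from compound 1 to compound 3 (0.26 log units; within the scatter) stayed within it. A six-membered aromatic ring with one hetero atom returns in compound 4, now as 6-amino-5-methylpyridin-3-yl, so a modest downward step is expected in this assay, though less certain than for pyridin-4-yl. Compound 4 is estimated at 9 nM (range 3 nM to 30 nM), meaning a 1.8-fold lower number from compound 3 to compound 4 (0.25 log units; within the scatter).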

Compound 4, half-maximal inhibitory concentration: 880 nM
Compound 4: middle estimate off by 98-fold (1.99 log units), on the low side, outside the stated range (above it).
By their numbers in this assay, from the lowest: compound 2; then compounds 3 and 1 (each within the scatter of the next); then compound 4.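

In this assay, a six-membered aromatic ring with one hetero atom does not in itself hold the number low at this position: 6-amino-5-methylpyridin-3-yl departs sharply from pyridin-4-yl (a 170-fold higher number from compound 2 to compound 4 (2.22 log units; beyond the scatter)) and from 2-methoxypyridin-4-yl (a 30-fold higher number from compound 1 to compound 4 (1.48 log units; beyond the scatter)). It also compares poorly with the five-membered ring (a 55-fold higher number from compound 3 to compound 4 (1.74 log units; beyond the scatter)), so the position is less permissive than the three earlier compounds suggested. No evidence at hand accounts for this rise. On these data alone, compound 4 carries the amine, the methyl and the pyridin-3-yl attachment together, so their separate contributions remain open. Unsubstituted pyridin-3-yl, or the same ring with only an amine or only a methyl, would separate them.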